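The source may hold more compounds than are shown below. What is called first, only, known or untested is meant among the compounds shown, and "the series" means these compounds.

Working notes on the series sharing the core of compound 1. In a functional assay on HCT-116 cells (Homo sapiens) for antiproliferative activity, read by MTT assay (a higher number here means a weaker inhibitor, a lower number a stronger inhibitor), compound 1 (`COc1cccc(/C=N/Nc2ncc3c(n2)n(C2CCCC2)c(=O)c(=O)n3C)c1`) gives 45800 nM, compound 2 (`Cn1c(=O)c(=O)n(C2CCCC2)c2nc(N/N=C/c3cccs3)ncc21`) gives 52600 nM and compound 3 (`Cn1c(=O)c(=O)n(C2CCCC2)c2nc(N/N=C/c3cccc([N+](=O)[O-])c3)ncc21`) gives 15200 nM. Compound 3 has the lowest number of the three, and its gaps to both others lie beyond the scatter.

The next structure, compound 4 (`Cn1c(=O)c(=O)n(C2CCCC2)c2nc(N/N=C/c3ccc(F)cc3F)ncc21`), carries 2,4-difluorophenyl in place of 3-nitrophenyl on a carbon with a double bond to nitrogen.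

For the measured compounds named here, two measured steps bear on this change, as each brings in the nitro compound: a 3.0-fold lower number from compound 1 to compound 3 (0.48 log units; beyond the scatter) and a 3.5-fold lower number from compound 2 to compound 3 (0.54 log units; beyond the scatter), both modest. The remaining step, a 1.1-fold higher number from compound 1 to compound 2 (0.06 log units; within the scatter), does not separate the two compounds without a nitro group. Going by the values given here, no fluorinated compound has been measured, so the range stays wide. A modest move towards a higher number in this assay is expected, reversing part of those two steps. The expected step is a 2.3-fold higher number from compound 3 to compound 4 (0.36 log units; beyond the scatter). For compound 4 the estimated value is 35000 nM, with an expected range from 13000 nM to 80000 nM.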

Compound 4, half-maximal inhibitory concentration: 19800 nM
Estimate against measurement, compound 4: 1.8-fold (0.25 log units) above; the measured number falls inside the stated range.
By their numbers in this assay, from the lowest: compounds 3 and 4 (each within the scatter of the next); then compounds 1 and 2 (each within the scatter of the next).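

In this assay, a nitro group is not required for the lower numbers at this position: 2,4-difluorophenyl, with no hydrogen-bond acceptors against the 2 of 3-nitrophenyl, gives a step that stays within the scatter (a 1.3-fold higher number from compound 3 to compound 4 (0.11 log units; within the scatter)). The same group stands clear of both remaining groups on the carbon with a double bond to nitrogen, with modest steps beyond the scatter (a 2.7-fold lower number from compound 2 to compound 4 (0.42 log units; beyond the scatter); a 2.3-fold lower number from compound 1 to compound 4 (0.36 log units; beyond the scatter)), so compound 3 and compound 4 sit together, apart from compound 1 and compound 2. No measurement bears on what underlies this separation.

Going by these compounds, it remains open whether a single fluorine would match 2,4-difluorophenyl at this place. Also open, on these data alone, is how a phenyl ring carrying an amine or a carboxylic acid would compare there.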